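Thiophene aminoketones: furan to pyrazole at the ring sulfur

The source may report more compounds than this note shows. Statements on the series, on what has been measured and on what is new or still open speak of the compounds shown alone.

Three members of the series have been run in an assay on CHO cells for displacement of a labelled ligand from adenosine receptor A3 (Homo sapiens), read by scintillation counting, tested at 10 uM; on this read-out higher numbers stand for more inhibition at the one concentration tested (going by the name of the read-out) and lower numbers for less inhibition. Compound 1 `CC(C)(C)Cc1csc(N)c1C(=O)c1cccc(Cl)c1` gives 8%, compound 2 `CC(C)(C)Cc1c(-c2ccoc2)sc(N)c1C(=O)c1ccc(Cl)cc1` gives 1%, and compound 3 `Cc1ccc(C(=O)c2c(N)sc(Br)c2CC(C)(C)C)cc1` gives 1%. Compound 2 sits at the same number as compound 3 at the digits shown, and compound 1 lies within the usual scatter of both, so the three values cannot be told apart; none of them shows notable displacement of the labelled ligand at the concentration used.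

Compound 4 `CC(C)(C)Cc1c(-c2cn[nH]c2)sc(N)c1C(=O)c1ccc(Cl)cc1` is yet to be measured in this assay. It differs from compound 2 in one place: 1H-pyrazol-4-yl in place of furan-3-yl on an aromatic carbon. Going by the values given here, no measured pair in the set separates the effect of such a swap, so the expectation rests on the flat values of compounds 1 to 3 alone. The step from compound 2 to compound 4 is estimated at a number 3 percentage points higher from compound 2 to compound 4 (within the scatter), that is none beyond the scatter, because compound 2 already stands at 1%. Compound 4 is therefore expected to give about 4%, with a range of -6% to 16%.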

Compound 4, a percentage reported as inhibition, at one concentration (the size of the read-out at that concentration, not a potency): 1%
For compound 4 the middle estimate is 3 percentage points above the measured one; low and high end bracket the measured number.
By their numbers in this assay, from the lowest: compounds 2, 3, 4 and 1 (each within the scatter of the next).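

In this assay, 1H-pyrazol-4-yl in place of furan-3-yl on the aromatic carbon next to the ring sulfur gives no change at the digits printed from compound 2 to compound 4 (within the scatter), the first one-place comparison available in this series. The entering group has 1 hydrogen-bond donor and 2 ring hetero atoms, against 0 donors and 1 ring hetero atom in the leaving group, and this pair shows no separation between the two at this position, though both compounds read so low that the pair says little about how much this position can matter. No available measurement bears on this result.

On these data alone, whether an aminomethyl group, a carboxylic acid or a longer alkyl chain at this position would give a clearly higher reading remains open. Also open, as far as these compounds go, is whether any group here can raise displacement above the low readings seen so far.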